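The compounds below may be only part of what the source reports. "The series", "measured", "known", "first", "only" and "open" are said of these compounds alone.

Compound 1 `COc1ccc(N2CCN(C(=O)C3(C)CCc4c(C)c(O)c(C)c(C)c4O3)CC2)cc1` gives 700 nM in a functional assay (brain) for inhibition, with Rattus norvegicus as the target (on this read-out lower numbers stand for stronger inhibition and higher numbers for weaker inhibition), and compound 2 `CCNc1cccnc1N1CCN(CC2(C)CCc3c(C)c(O)c(C)c(C)c3O2)CC1` gives 1000 nM. Within the data shown here, of the two numbers, the one for compound 2 is the higher, a gap to compound 1 that lies within the scatter. Compound 3 `COc1ccc(N2CCN(CC3(C)CCc4c(C)c(O)c(C)c(C)c4O3)CC2)cc1` has yet to be measured in this assay. Relative to compound 2 the change is 4-methoxyphenyl in place of 3-(ethylamino)pyridin-2-yl on an amine nitrogen in a ring. Among the measured compounds shown here, no measured pair isolates this change; with the two available values sitting close together, the step from compound 2 to compound 3 is expected to stay within the scatter, a 1.3-fold lower number from compound 2 to compound 3 (0.10 log units; within the scatter). For compound 3 the estimate in this assay is 800 nM, ranging from 300 nM to 2200 nM.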

Compound 3, half-maximal inhibitory concentration: 200 nM
Beside the measured number, compound 3's estimate is 4.0-fold (0.60 log units) above it, and the stated range ends above it.
By their numbers in this assay, from the lowest: compound 3; then compounds 1 and 2 (each within the scatter of the next).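

In this assay, putting 4-methoxyphenyl in place of 3-(ethylamino)pyridin-2-yl on the amine nitrogen in the ring gives a 5.0-fold lower number from compound 2 to compound 3 (0.70 log units; beyond the scatter). The group at this position therefore moves the number beyond the scatter, which the two earlier values, close together and from compounds differing in more than one place, could not show. Nothing available accounts for the size of this step.

From the compounds shown here alone, the change replaces the ring and its substituent together, so their separate contributions remain open. An unsubstituted phenyl or a 3-(ethylamino)phenyl at this position would separate them.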